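The compounds below may be only part of what the source reports. "The series", "measured", "known", "first", "only" and "open" are said of these compounds alone.

Three compounds have so far been measured in a functional assay on A549 cells (Homo sapiens) for inhibition; on this read-out higher numbers stand for weaker inhibition and lower numbers for stronger inhibition:

compound 1 `CCc1ccc(N2C(=O)C=CC2OCC(F)(F)F)cc1` gives 8090 nM;
compound 2 `Cc1ccc(N2C(=O)C=CC2OCC(F)(F)F)cc1` gives 13700 nM;
compound 3 `O=C1C=CC(OCC(F)(F)F)N1c1cc(F)cc(F)c1` gives 5000 nM.

Among these, compound 2 shows the highest of the three numbers in this assay. Its nearest neighbour is compound 1, separated from it by a 1.7-fold higher number from compound 1 to compound 2 (0.23 log units; within the scatter), a step that lies within the scatter; compound 3 stands furthest from it, beyond the scatter.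

Compound 4 `CC(C)(C)c1ccc(N2C(=O)C=CC2OCC(F)(F)F)cc1` has not yet been measured. It differs from compound 2 by tert-butyl in place of methyl on an aromatic carbon. Among the compounds with values here, the only measured step that bears on this change is the one between compound 1 and compound 2, a 1.7-fold higher number from compound 1 to compound 2 (0.23 log units; within the scatter), where hydrogen took the place of methyl on the saturated chain and the number rose by an amount inside the scatter. Compound 4 runs the opposite way and goes further, with tert-butyl entering where methyl stood. If the direction of a 1.7-fold higher number from compound 1 to compound 2 (0.23 log units; within the scatter) holds when read backwards, a somewhat lower number is expected for compound 4, but since that single step is itself within the scatter, no change beyond the scatter can be counted on. Compound 4 is therefore estimated to give 7500 nM, with a range from 3500 nM to 16000 nM. The expected step is a 1.8-fold lower number from compound 2 to compound 4 (0.26 log units; within the scatter), which is estimated to remain close to the scatter.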

Compound 4, half-maximal inhibitory concentration: 8500 nM
The estimate for compound 4 lay 1.1-fold (0.05 log units) below the measured number, within the range that was stated.
By their numbers in this assay, from the lowest: compounds 3, 1, 4 and 2 (each within the scatter of the next, the first and the last beyond it).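

On the aromatic carbon para to a large group, tert-butyl in place of methyl raises the size of the group from 1 heavy atom to 4 heavy atoms, yet in this assay this gives only a 1.6-fold lower number from compound 2 to compound 4 (0.21 log units; within the scatter). Tert-butyl in place of ethyl at the same place gives a 1.1-fold higher number from compound 1 to compound 4 (0.02 log units; within the scatter), so the earlier reading between methyl and ethyl now extends to a branched group: across these three alkyl groups, no step leaves the scatter, and the series gives no sign that the number at this position follows the size of the group. No measurement is available that would explain this reading.

The compounds shown leave open whether a group of another kind at this position, such as an amine, a carboxylic acid or a methoxy group, would produce a step beyond the scatter. They also leave open whether a longer chain, such as an octyl group, or a phenyl ring at the same place would stay as close to these three alkyl compounds as they stay to one another.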